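The compounds below may be only part of what the source reports. "The series", "measured", "known", "first", "only" and "open" are said of these compounds alone.

Measured in a functional assay on NCI-H929 cells (Homo sapiens) for cytotoxicity, read by MTT assay, with a stated time of 72 h (a higher number here means a weaker inhibitor, a lower number a stronger inhibitor), so far:

- compound 1 `C=C1C2=C(C(=O)N1OC)[C@H](OC(=O)CSc1nc3ccccc3o1)[C@@](C)(O)[C@H](CCCCC)O2` gives 3000 nM
- compound 2 `C=C1C2=C(C(=O)N1OC)[C@H](OC(=O)CCCCCl)[C@@](C)(O)[C@H](CCCCC)O2` gives 2500 nM
- compound 3 `C=C1C2=C(C(=O)N1OC)[C@H](OC(=O)CSc1nc3ccccc3[nH]1)[C@@](C)(O)[C@H](CCCCC)O2` gives 2000 nM

Compound 3 lies within the scatter of both other compounds, so these three values set no order among them.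

Compound 4 `C=C1C2=C(C(=O)N1OC)[C@H](OC(=O)CCl)[C@@](C)(O)[C@H](CCCCC)O2` has not yet been measured. It differs from compound 3 by one change: chloro in place of (1H-benzimidazol-2-yl)sulfanyl on a saturated chain carbon bound to a carbonyl carbon. In words, this is chloro in place of (1H-benzimidazol-2-yl)sulfanyl on a saturated chain carbon bound to a carbonyl carbon.

For the measured compounds named here, three measured steps bear on this change. Exchanging only the ring on the sulfur gives a 1.5-fold lower number from compound 1 to compound 3 (0.18 log units; within the scatter). Exchanging the whole group on that same carbon gives a 1.2-fold lower number from compound 1 to compound 2 (0.08 log units; within the scatter) and also a 1.3-fold lower number from compound 2 to compound 3 (0.10 log units; within the scatter). All three stay within the scatter, even though the groups exchanged are quite different. However, no measured compound carries a group as small as chloro at this place, so the evidence is indirect and the range should stay wide.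

In this assay no step beyond the scatter is therefore expected, and no direction can be called. The expected change is a 1.3-fold higher number from compound 3 to compound 4 (0.10 log units; within the scatter) and remains within the scatter. For compound 4 the estimated value is 2500 nM with an expected range from 1100 nM to 5500 nM as the likely span.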

Compound 4, half-maximal inhibitory concentration: 3300 nM
Compound 4: middle estimate off by 1.3-fold (0.12 log units), on the low side; low and high end bracket the measured number.
By their numbers in this assay, from the lowest: compounds 3, 2, 1 and 4 (each within the scatter of the next).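

In this assay, replacing the larger groups on the saturated chain carbon bound to a carbonyl carbon with a lone chloro gives a 1.7-fold higher number from compound 3 to compound 4 (0.22 log units; within the scatter) and a 1.3-fold higher number from compound 2 to compound 4 (0.12 log units; within the scatter) and also a 1.1-fold higher number from compound 1 to compound 4 (0.04 log units; within the scatter) and so leaves all three steps within the scatter. The earlier compounds showed this flat picture only for larger groups, whereas chloro has no ring and no hydrogen-bond donor, so neither the rings of the (1H-benzimidazol-2-yl)sulfanyl group nor its hydrogen-bond donor is shown to be needed for this level of cytotoxicity. No supporting measurement is available to explain why such different groups give such similar numbers.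

Still open, on these data alone, is whether any group at this place can move the number beyond the scatter, for example an amine, a carboxylic acid or a longer chain ending in a phenyl ring. As far as these compounds go, the shared core is the same in all four compounds, so what its parts contribute to the cytotoxicity remains untested by these data.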